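Oxazolidinone series: side-chain variation and lipophilicity

A few compounds are considered here, and "the series" means these few. Any claim that something is new, unique, unknown or untested is made for them only; others in the source may bear on it.

Measured so far:
compound 1, `CN(CCC#N)C[C@H]1CN(c2ccc(-n3cc(-c4ccccn4)cn3)c(F)c2)C(=O)O1`: 1.9
compound 2, `O=C1CCC(=O)N1C[C@H]1CN(c2ccc(-n3cc(-c4ccccn4)cn3)c(F)c2)C(=O)O1`: 1.58
compound 3, `O=C1O[C@@H](Cn2ccnn2)CN1c1ccc(-n2cc(-c3ccccn3)cn2)c(F)c1`: 2

In a physicochemical assay for lipophilicity, read by HPLC, measured as octanol-water partition (a lower number here means a more polar compound, a higher number a more lipophilic compound), compound 3 returns the highest of the three numbers, but this ranking is only partly secure: a number 0.10 log units higher from compound 1 to compound 3 (within the scatter) falls within the scatter, so compound 1 and compound 3 cannot be told apart, whereas a number 0.42 log units higher from compound 2 to compound 3 (beyond the scatter) stands beyond it. Among the compounds with values here, the one step that is clearly beyond the scatter among the measured pairs is a number 0.32 log units lower from compound 1 to compound 2 (beyond the scatter), in the same modest range.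

Compound 4 is `CONC(=O)[C@H]1CN(c2ccc(-n3cc(-c4ccccn4)cn3)c(F)c2)C(=O)O1`, still to be measured in this assay. It differs from compound 3 as follows: methoxycarbamoyl in place of (1H-1,2,3-triazol-1-yl)methyl on a saturated ring carbon

Within the data shown here, none of the measured steps exchanges a group for methoxycarbamoyl, and none acts on the saturated ring carbon; all three vary the group on the saturated chain carbon. They do show how wide the spread at this end of the shared core has been so far, with a number 0.42 log units higher from compound 2 to compound 3 (beyond the scatter) as the largest move. A modest move downward, roughly the size of that step reversed, is expected here, which gives a number 0.40 log units lower from compound 3 to compound 4 (beyond the scatter) as the estimate. For compound 4 the expected value in this assay is 1.6, with a range from 1.2 to 2.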

Compound 4, partition coefficient: >= 1.58
Compound 4 was reported as a limit (the forecaster's own chance of this, stated with the estimate: 0%); the middle value is on the limit's open side.
By their numbers in this assay, from the lowest: compound 2; then compounds 1 and 3 (each within the scatter of the next).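

In this assay compound 4 gives >= 1.58, which is a limit and not a number. Within the data shown here, it is the first entry in which the change falls on the saturated ring carbon itself, with methoxycarbamoyl, carrying 1 hydrogen-bond donor, entering where (1H-1,2,3-triazol-1-yl)methyl, with 0 hydrogen-bond donors, leaves, and the only direction on offer is a number no lower from compound 2 to compound 4 (the limit leaves the size open). Among these compounds, the steps to compound 4 from compound 1 and from compound 3 cannot be read, so this change places compound 4 relative to compound 2 alone and gives no size for any step.

Still open, from the compounds shown here alone, is where compound 4 stands relative to compound 1 and compound 3, since only a number in place of the limit would settle it. Also open, going by these compounds, is how a carboxylic acid or a plain primary amide on the same saturated ring carbon, or the methoxycarbamoyl group carried on a longer chain, would read in this assay.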